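The source may report more compounds than this note shows. Statements on the series, on what has been measured and on what is new or still open speak of the compounds shown alone.

Compound 2 `CC(=O)Nc1nn(-c2ccccc2)c(=O)c2ccccc12` gives the higher of the two measured numbers in an assay on CHO cells for displacement of a labelled ligand from adenosine receptor A1 (Homo sapiens), tested at 10 uM; on this read-out lower numbers stand for less inhibition and higher numbers for more inhibition at the one concentration tested (going by the name of the read-out): compound 2 gives 52%, whereas compound 1 `COc1ccccc1CNC(=O)Nc1nn(-c2ccccc2)c(=O)c2ccccc12` gives 28%. Among the measured compounds shown here, the one measured step, a number 24 percentage points higher from compound 1 to compound 2 (beyond the scatter), shows that trading an amino substituent on the carbonyl carbon for a methyl raised the read-out. Compound 3 `Cc1ccccc1NC(=O)Nc1nn(-c2ccccc2)c(=O)c2ccccc12` reverses that kind of change: (2-methylphenyl)amino in place of methyl on a carbonyl carbon. For the measured compounds named here, since the only relevant step ran from a carbonyl-linked amino group to methyl and gained modestly, putting an amino group back on that carbon, here (2-methylphenyl)amino rather than (2-methoxybenzyl)amino, is expected to cost a similar amount, though the new group differs from the one in compound 1, so the size is uncertain. The step is therefore estimated as a number 22 percentage points lower from compound 2 to compound 3 (beyond the scatter), downward and beyond the scatter. Compound 3 is expected to reach 30% in this assay, within a range from 10% to 50%.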

Compound 3, a percentage reported as inhibition, at one concentration (the size of the read-out at that concentration, not a potency): 20%
Beside the measured number, compound 3's estimate is 10 percentage points above it; the range from low to high includes it.
By their numbers in this assay, from the lowest: compounds 3 and 1 (each within the scatter of the next); then compound 2.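

Measured in this assay, (2-methylphenyl)amino in place of methyl on the carbonyl carbon brings a number 32 percentage points lower from compound 2 to compound 3 (beyond the scatter) and is a large step, so the loss at this position is not tied to the (2-methoxybenzyl)amino group alone. Replacing 2-methoxybenzyl with 2-methylphenyl on the amide-type nitrogen gives a number 8 percentage points lower from compound 1 to compound 3 (within the scatter), so this read-out does not separate these two substituents. Both compounds with a substituted amino group on the carbonyl carbon therefore lie below compound 2, and none of the three compounds goes against this.

Nothing available explains why methyl on this carbon gives the higher number. From the compounds shown here alone, it remains open whether an unsubstituted amino group, dimethylamino or a longer chain such as propyl would keep the number of compound 2, and whether the amino nitrogen or the added ring accounts for the loss.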